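Removing the hydroxy group from compound 2

This account rests on a few compounds, and the source may have more. Where it says the series, first, only, none or still open, it means among the compounds named here.

In a functional assay on WRL68 cells (Homo sapiens) for cytotoxicity, read by MTT assay, with stated times of 6 h and 48 h (on this read-out lower numbers stand for stronger inhibition and higher numbers for weaker inhibition), compound 1 `Cn1c(/C=C/C(=O)c2ccccc2)cc(Br)c1Br` gives >= 100000 nM, which is a limit and not a number. Within the data shown here, compound 2 `O=C(/C=C/c1cc(Br)c(Br)[nH]1)c1ccccc1O` gives 1420 nM, the only actual number so far. Compound 3 `O=C(/C=C/c1cc(Br)c(Br)[nH]1)c1ccccc1` departs from compound 2 by hydrogen in place of hydroxy on an aromatic carbon, ortho to a large group. Among the measured compounds shown here, no measured pair isolates this change, so the direction is only a judgement. In this assay, a weakening beyond the scatter is expected, a 5.6-fold higher number from compound 2 to compound 3 (0.75 log units; beyond the scatter). Compound 3 is estimated at 8000 nM, with an expected range of 1500 nM to 60000 nM.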

Compound 3, half-maximal inhibitory concentration: >= 100000 nM
Compound 3 ended at the assay's limit; the forecaster's own chance of this, stated with the estimate: 20%; at least 12-fold (1.09 log units) between middle value and limit.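

Hydrogen in place of hydroxy on this aromatic carbon, ortho to a large group, gives an at least 70-fold higher number from compound 2 to compound 3 (1.84 log units; beyond the scatter) in this assay, the first readable step in the series and a large one. Compound 3 gives a limit and not a number, so this step is a minimum. Compound 2 is the only compound with an actual number here: the limit of >= 100000 nM in this assay, at which 2 of the 3 values shown sit.

The step between compound 1 and compound 3 cannot be read, which leaves hydrogen in place of methyl on the aromatic nitrogen unresolved. As far as these compounds go, whether a methoxy group or an amine on this aromatic carbon would give a number near that of compound 2 stays open.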